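The compounds below may be only part of what the source reports. "The series", "measured", "known", "first", "only" and "open" are said of these compounds alone.

The measured compounds in a functional assay on MDA-MB-231 cells (Homo sapiens) for antiproliferative activity, read by MTT assay, with a stated time of 48 h; a higher number here means a weaker inhibitor, a lower number a stronger inhibitor:
Compound 1 `O=C(Nc1cc(Sc2ncn[nH]2)c(O)c2ccccc12)c1cccc([N+](=O)[O-])c1` gives 48000 nM.
Compound 2 `O=C(Nc1cc(Sc2ncn[nH]2)c(O)c2ccccc12)c1ccc2ccccc2c1` gives 45100 nM.
Compound 3 `O=C(Nc1cc(Sc2nncs2)c(O)c2ccccc12)c1ccc(Cl)cc1` gives > 100000 nM, which is a limit of the assay and not a number.

Among the two numbers, compound 1 stands highest, with compound 2 nearest and a 1.1-fold lower number from compound 1 to compound 2 (0.03 log units; within the scatter). Compound 4 `O=C(Nc1cc(Sc2ncn[nH]2)c(O)c2ccccc12)c1ccc(Cl)cc1` differs from compound 1 by 4-chlorophenyl in place of 3-nitrophenyl on a carbonyl carbon. Going by the values given here, the one step that bears on this place, exchanging the aryl group on the carbonyl carbon, stayed within the scatter; compound 3 carries the same 4-chlorophenyl group on a different core, and the assay returned only a limit there. So compound 4 is expected to sit near compound 1, a 1.3-fold higher number from compound 1 to compound 4 (0.10 log units; within the scatter), with an estimated 60000 nM in this assay, between 25000 nM and 150000 nM.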

Compound 4, half-maximal inhibitory concentration: 25700 nM
For compound 4 the middle estimate is 2.3-fold (0.37 log units) above the measured one; the range from low to high includes it.
By their numbers in this assay, from the lowest: compounds 4, 2 and 1 (each within the scatter of the next). At a limit, above all of these: compound 3.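

Exchanging the aryl group on the carbonyl carbon for 4-chlorophenyl again stays within the scatter (a 1.9-fold lower number from compound 1 to compound 4 (0.27 log units; within the scatter)) and (a 1.8-fold lower number from compound 2 to compound 4 (0.24 log units; within the scatter)). Going by these compounds alone, the exchange on the sulfur, 1H-1,2,4-triazol-5-yl in place of 1,3,4-thiadiazol-2-yl, gives the only step beyond the scatter (an at least 3.8-fold lower number from compound 3 to compound 4 (0.59 log units; beyond the scatter)). Compound 3 stands at a limit of the assay and not a number: the limit of > 100000 nM in this assay, at which 1 of the 4 values shown sits.

The compounds shown leave open how an amine or a carboxylic acid on the aryl ring would compare. They also leave open how an open alkyl chain on the sulfur would compare with either ring.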